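This account rests on a few compounds, and the source may have more. Where it says the series, first, only, none or still open, it means among the compounds named here.

Compound 1 `CC(C)[C@H](NC(=O)CN(c1nc(Cl)nc2[nH]cnc12)C1CC1)C(=O)OCc1ccccc1` gives 51.3% in a functional assay on the whole organism (Tail, strain ICR) with Mus musculus as the target, in the tail flick test, with a stated time of 90 min, at a dose of 25 umol/kg by the oral route; on this read-out higher numbers stand for a stronger effect at the one dose given and lower numbers for a weaker effect. Compound 3 `O=C(OCc1ccccc1)[C@@H]1CCCN1C(=O)CN(c1nc(Cl)nc2[nH]cnc12)C1CC1` gives 43.3% in this assay, a number within the scatter of compound 1, so no order can be set between the two. Compound 2 `O=C(CN(c1ncnc2c1ncn2C1CCCCO1)C1CC1)NCC(=O)OCc1ccccc1` gives 25.9%, which lies beyond the scatter below compound 1. Compound 1 thus holds the highest of the three numbers shown, though only compound 2 stands apart from it beyond the scatter. Compound 4 `CC[C@H](C)[C@H](NC(=O)CN(c1nc(Cl)nc2[nH]cnc12)C1CC1)C(=O)OCc1ccccc1` has not yet been measured. It differs from compound 1 in one place: methyl in place of hydrogen on a saturated chain carbon, three bonds along the chain from an amide-type nitrogen and a carbonyl carbon. Going by the values given here, no step between measured compounds covers such a change, so the expectation rests on the small size of the change alone. The step of a number 1.3 percentage points lower from compound 1 to compound 4 (within the scatter) is expected to stay within the scatter, in either direction. Compound 4 is estimated at 50%, with a range from 30% to 70%.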

Compound 4, a percentage reported as activity, at one dose (the size of the read-out at that dose, not a potency): 36.3%
Compound 4: middle estimate off by 13.7 percentage points, on the high side; low and high end bracket the measured number.
By their numbers in this assay, from the lowest: compound 2; then compounds 4, 3 and 1 (each within the scatter of the next, the first and the last beyond it).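

In this assay, the change from isopropyl to sec-butyl gives a number 15 percentage points lower from compound 1 to compound 4 (beyond the scatter), the first step read at this place. A single added methyl on this saturated chain carbon is thus enough to move the number beyond the scatter, and the direction is downward. Nothing shown bears on the reason for this fall.

On these data alone, whether a longer chain, such as n-pentyl, would lower the number further remains open. So does the outcome of placing a hydroxyl group or an amine on this carbon.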